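From Fluoro to Trifluoromethyl at the Limit of Detection

This account rests on a few compounds, and the source may have more. Where it says the series, first, only, none or still open, it means among the compounds named here.

In a functional assay on KYSE-70 cells for antiproliferative activity against KYSE-70 cell line (Homo sapiens), read by MTT assay, with a stated time of 72 h (on this read-out lower numbers stand for stronger inhibition and higher numbers for weaker inhibition), compound 1 (`O=C(Nc1cccc(F)c1)c1cc(=O)[nH]c2cc(F)ccc12`) gives > 20000 nM, which is a limit and not a number. Compound 2 (`O=C(Nc1cc(F)cc(F)c1)c1cc(=O)[nH]c2cc(F)ccc12`) gives > 20000 nM, also a limit. Both compounds stand at the limit of > 20000 nM in this assay, at which 2 of the 2 values shown sit. For the measured compounds named here, the one measured step is a step that the two limits leave unreadable from compound 1 to compound 2, and it offers no size to carry forward. Compound 3 (`O=C(Nc1cc(F)cc(F)c1)c1cc(=O)[nH]c2cc(C(F)(F)F)ccc12`) departs from compound 2 on the shared core: trifluoromethyl in place of fluoro on an aromatic carbon. Going by the values given here, this places trifluoromethyl in place of fluoro on an aromatic carbon, a change that no measured step covers. As far as these compounds go, with no readable step to build on, no shift beyond the scatter is expected in this assay, although a slight move towards stronger inhibition remains open. The expected step is an at least 1.1-fold lower number from compound 2 to compound 3 (0.04 log units; that floor lies within the scatter). Compound 3 is estimated at 18000 nM, with an expected range of 6000 nM to 30000 nM.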

Compound 3, half-maximal inhibitory concentration: 14200 nM
Compound 3: middle estimate off by 1.3-fold (0.10 log units), on the high side; the measured number falls inside the stated range.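

In this assay, compound 3 is the first of the compounds shown to give a number and not a limit, so this aromatic carbon of the shared core now has a readable result. Trifluoromethyl in place of fluoro gives an at least 1.4-fold lower number from compound 2 to compound 3 (0.14 log units; that floor lies within the scatter), which shows only that the number lies on the side of stronger inhibition and does not establish a shift beyond the scatter. The value of compound 2 is a limit, as is that of compound 1, so the step between those two cannot be read and the true size of the new step remains unfixed: the limit of > 20000 nM in this assay, at which 2 of the 3 values shown sit.

The compounds shown leave open how this aromatic carbon responds to a group such as a nitrile, an amine or a carboxylic acid. They also leave open whether any such replacement for trifluoromethyl would move the number beyond the scatter.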